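Swapping Trichloromethyl for Phenyl at a Hydrolysable Arm

A few compounds are considered here, and "the series" means these few. Any claim that something is new, unique, unknown or untested is made for them only; others in the source may bear on it.

Of the compounds shown here, three sharing one core have been measured in an ADME assay (intestine, Homo sapiens) for pharmacokinetics, using microsomes; a lower number here means that the compound disappears faster, a higher number that the compound lasts longer. Compound 1, `CCOc1cc(NC(=O)C2(NC(=O)c3ccc4c(C5CCCC5)c(-c5ncc(Cl)cn5)n(C)c4c3)CCC2)ccc1/C=C/C(=O)OCOP(=O)(O)O`, carries a phosphorus-containing group on a saturated chain carbon bound to an oxygen next to a carbonyl group, and in this assay compound 1 gives 0.467 h. Compound 2, `CCOC(=O)/C=C/c1ccc(NC(=O)C2(NC(=O)c3ccc4c(C5CCCC5)c(-c5ncc(Cl)cn5)n(C)c4c3)CCC2)cc1OCC`, has a methyl in that place; its value in this assay, > 5 h, is a limit of the assay rather than a number. Compound 3, `CCOc1cc(NC(=O)C2(NC(=O)c3ccc4c(C5CCCC5)c(-c5ncc(Cl)cn5)n(C)c4c3)CCC2)ccc1/C=C/C(=O)OCC(Cl)(Cl)Cl`, carries a trichloromethyl there, and in this assay compound 3 likewise reaches only a limit, > 5 h. The two steps away from the phosphorus group were large: an at least 10-fold higher number from compound 1 to compound 2 (1.02 log units; beyond the scatter) and an at least 10-fold higher number from compound 1 to compound 3 (1.02 log units; beyond the scatter). Between the two limits, a step that the two limits leave unreadable from compound 2 to compound 3. Compound 3 thus stands at the upper boundary of what the measurement can report, as does compound 2 (the limit of > 5 h in this assay, at which 2 of the 3 values shown sit).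

Compound 4, `CCOc1cc(NC(=O)C2(NC(=O)c3ccc4c(C5CCCC5)c(-c5ncc(Cl)cn5)n(C)c4c3)CCC2)ccc1/C=C/C(=O)OCc1ccccc1`, differs from compound 3 in one place: phenyl in place of trichloromethyl on a saturated chain carbon bound to an oxygen next to a carbonyl group. Among the compounds with values here, no measured step involves a phenyl in this place, so the only guide is that both groups lacking phosphorus sit at the limit. The phosphorus-bearing compound 1 sits far lower at 0.467 h. Compound 4 is therefore expected to stay long-lived, the estimated step of an at least 1.2-fold lower number from compound 3 to compound 4 (0.09 log units; that floor lies within the scatter) pointing to roughly 4 h, within 1.5 h to 8 h.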

Compound 4, half-life: > 5 h
Compound 4 ended at the assay's limit (the forecaster's own chance of this, stated with the estimate: 40%); middle value at least 1.2-fold (0.09 log units) from the limit.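

In this assay, the place on the saturated chain carbon bound to an oxygen next to a carbonyl group now holds a ring as well as the smaller groups: compound 4, with its phenyl, ends at the same limit as compound 2, with its methyl, and compound 3, with its trichloromethyl, so groups that differ this much in atoms and shape cannot be told apart here: the limit of > 5 h in this assay, at which 3 of the 4 values shown sit.

The change away from the phosphorus-containing group is again large, an at least 10-fold higher number from compound 1 to compound 4 (1.02 log units; beyond the scatter), which makes compound 1 the only one of the four with a short half-life that can be read as a number. The steps among compound 2, compound 3 and compound 4 cannot be read, so no order among them can be given.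

As far as these compounds go, how far each of these three lasts beyond the limit remains unknown, and real differences among them could be hidden there. Also open, from the compounds shown here alone, is whether a carboxylic acid or an amine on that same chain carbon would stay at the limit or fall towards compound 1.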